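Toward compound 4: a cyano group replaces chloro

The source may hold more compounds than are shown below. What is called first, only, known or untested is meant among the compounds shown, and "the series" means these compounds.

The compounds measured so far, with their half-maximal cytotoxic concentrations:
compound 1 `COc1ccnc(Nc2ccc(Cl)c(OCC=C(C)C)c2)n1`: 9000 nM
compound 2 `CNc1ccnc(Nc2ccc(Cl)c(OCC=C(C)C)c2)n1`: 690 nM
compound 3 `CSc1ccnc(Nc2ccc(Cl)c(OCC=C(C)C)c2)n1`: 2800 nM

In an ADME assay on MT2 cells (Homo sapiens) for cytotoxicity (on this read-out higher numbers stand for lower toxicity in this test and lower numbers for higher toxicity in this test), compound 2 gives the lowest number of the three; compound 3 stands nearest at a 4.1-fold higher number from compound 2 to compound 3 (0.61 log units; beyond the scatter), and compound 1 furthest at a 13-fold lower number from compound 1 to compound 2 (1.12 log units; beyond the scatter). Compound 4 `CNc1ccnc(Nc2ccc(C#N)c(OCC=C(C)C)c2)n1` keeps the methylamino group of compound 2 and differs only on the other ring: cyano in place of chloro on an aromatic carbon. Among the compounds with values here, none of the measured steps touches that ring; all three steps, including a 3.2-fold lower number from compound 1 to compound 3 (0.51 log units; beyond the scatter), change the group on the shared core. Within the data shown here, no comparable step is therefore at hand, and compound 4 is expected to show no step beyond the scatter, estimated at a 1.3-fold higher number from compound 2 to compound 4 (0.12 log units; within the scatter). Compound 4 is thus estimated at 900 nM, within 300 nM to 3000 nM.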

Compound 4, half-maximal cytotoxic concentration: 22 nM
For compound 4 the middle estimate is 41-fold (1.61 log units) above the measured one; measured number below the stated range.
By their numbers in this assay, from the lowest: compound 4; then compound 2; then compound 3; then compound 1.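

Within the data shown here, the ring carrying the (3-methylbut-2-en-1-yl)oxy group, untouched by the earlier steps, proves able to change the read-out strongly: in this assay cyano in place of chloro gives a 31-fold lower number from compound 2 to compound 4 (1.50 log units; beyond the scatter) and so marks higher toxicity in this test. This large step comes from a change at a single aromatic carbon, with the methylamino group held constant. Nothing measured here accounts for this step. The compounds shown leave open whether cyano has a similar effect alongside methoxy or methylsulfanyl on the shared core. They also leave open where a bromo, trifluoromethyl or carboxamide group at this carbon would fall.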